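This account rests on a few compounds, and the source may have more. Where it says the series, first, only, none or still open, it means among the compounds named here.

Compound 1, `NCC(O)Cn1c(=O)n(C2OC(CO)[C@@H](O)[C@H]2O)c2nc(N)nc(O)c21`: 110%
Compound 2, `C=CCn1c(=S)n(C2OC(COCc3ccccc3)[C@H]3OC(C)(C)O[C@@H]23)c2nc(N)nc(O)c21`: 77%
Compound 3, `C=CCn1c(=O)n(C2C[C@H](O)C(CO)O2)c2nc(N)nc(O)c21`: 99%

Of the compounds shown here, three have been measured in a functional assay on the whole organism (B cells) with Mus musculus as the target; a higher number here means a larger maximal response, a lower number a smaller maximal response. Compound 1 gives the highest of the three numbers, 110%. The nearest to it is compound 3, whose value lies lower by a margin beyond the usual scatter, and the furthest is compound 2, lower still by a margin also beyond the scatter. Within the data shown here, these three share a common core and differ in several places at once, so no single step between them can be separated out.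

Compound 4, `N#Cc1ccc(Cn2c(=O)n(C3OC(CO)[C@@H](O)[C@H]3O)c3nc(N)nc(O)c32)cc1`, has not yet been measured in this assay . Relative to compound 1 the change is 4-cyanophenyl in place of 2-amino-1-hydroxyethyl on a saturated chain carbon bound to an aromatic nitrogen. Among the measured compounds shown here, with no step between measured compounds to lean on, only the spread of the three measured values gives a sense of scale, and that spread covers a moderate range. A small downward step is expected for compound 4, one that may well stay within the scatter, a number 12 percentage points lower from compound 1 to compound 4 (beyond the scatter). Compound 4 is therefore estimated at 98% in this assay , with a range from 72% to 118%.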

Compound 4, largest response reached (reported as maximal response), in percent of the reference or control that the assay uses: 50%
Estimate against measurement, compound 4: 48 percentage points above, outside the stated range (below it).
By their numbers in this assay, from the lowest: compound 4; then compound 2; then compound 3; then compound 1.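

In this assay, the group on this saturated chain carbon bound to an aromatic nitrogen matters a great deal: 4-cyanophenyl in place of 2-amino-1-hydroxyethyl gives a large fall, a number 60 percentage points lower from compound 1 to compound 4 (beyond the scatter). The earlier compounds shown here differed in several places at once, whereas this single change shows that the response is sensitive to this one place on the shared core. Nothing measured here explains the fall.

This one swap removes a chain with two hydrogen-bond donors and brings in an aromatic ring with none, plus a nitrile, so it cannot show which of these differences accounts for the drop. A plain phenyl without the nitrile, or a chain carrying the amine but not the hydroxyl, would be needed to pull those differences apart.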